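Hydroxy for nitro on the aryl ring of compound 1

A few compounds are considered here, and "the series" means these few. Any claim that something is new, unique, unknown or untested is made for them only; others in the source may bear on it.

The series shares one core, a purine-dione carrying a substituted phenyl group, and is read in an assay for binding affinity to adenosine receptor A1 (Bos taurus); on this read-out lower numbers stand for stronger inhibition and higher numbers for weaker inhibition. Compound 1 `Cn1c(=O)c2nc(-c3cccc([N+](=O)[O-])c3)[nH]c2n(C)c1=O` bears a nitro on the phenyl ring; in this assay compound 1 gives 50 nM, the highest number among the three measured compounds. Compound 2 `CCc1ccc(-c2nc3c(=O)n(C)c(=O)n(C)c3[nH]2)cc1` carries an ethyl on the ring and in this assay compound 2 gives 0.8 nM. Compound 3 `Cn1c(=O)c2nc(-c3ccc(Cl)cc3N)[nH]c2n(C)c1=O` carries a chlorine and an amino on the ring, and in this assay compound 3 gives 0.35 nM. Both gaps from compound 1, to compound 2 and to compound 3, lie beyond the scatter of this assay, so compound 1 is the weakest binder of the three.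

Compound 4 `Cn1c(=O)c2nc(-c3cccc(O)c3)[nH]c2n(C)c1=O` is not yet measured. Within the data shown here, it differs from compound 1 by hydroxy in place of nitro on an aromatic carbon; no measured pair shows this same exchange, so the size of the step must be guessed from the surrounding values. Every measured substitution other than the nitro of compound 1 sits at a lower number, so a move toward stronger binding is expected. The estimated step from compound 1 to compound 4 is a 5.0-fold lower number from compound 1 to compound 4 (0.70 log units; beyond the scatter), a change beyond the scatter. For compound 4 the expected value in this assay is 10 nM, within 2 nM to 50 nM.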

Compound 4, half-maximal inhibitory concentration: 6 nM
Compound 4: the middle estimate sits 1.7-fold (0.22 log units) above what was measured; low and high end bracket the measured number.
By their numbers in this assay, from the lowest: compound 3; then compound 2; then compound 4; then compound 1.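

In this assay, among these compounds, the exchange on an aromatic carbon meta to a large group gives an 8.3-fold lower number from compound 1 to compound 4 (0.92 log units; beyond the scatter), the first single-place step and one beyond the scatter. It shows that the number responds to the group at this position and that the nitro of compound 1 can be replaced here by a hydroxy without a loss of binding; the change removes 3 heavy atoms with 0 hydrogen-bond donors and brings in 1 heavy atom with 1 hydrogen-bond donor, and this single pair cannot separate those differences. No supporting measurement accounts for the size of the step.

Going by these compounds, whether the gain comes from losing the nitro or from gaining the hydrogen-bond donor stays open, and a methoxy, an amine or a carboxylic acid on the same aromatic carbon would help to separate the two. Among the compounds shown here, compound 2 and compound 3 differ from compound 1 and compound 4 in more than one place, so no steps to them can be read, and whether the hydroxy behaves alike elsewhere on the ring also remains unknown.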